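A few compounds are considered here, and "the series" means these few. Any claim that something is new, unique, unknown or untested is made for them only; others in the source may bear on it.

Values in an ADME assay on 184B5 cells (Homo sapiens) for cytotoxicity, read by MTT assay, with a stated time of 72 h (on this read-out higher numbers stand for weaker inhibition of growth and lower numbers for stronger inhibition of growth), for the measured compounds:

compound 1, `C=CCOC(=O)Nc1ccc([Se]C#N)cc1`: 9800 nM
compound 2, `N#C[Se]c1ccc(NC(=O)Oc2ccccc2)cc1`: 22700 nM
compound 3, `N#C[Se]c1ccc(NC(=O)Oc2ccc(Cl)cc2)cc1`: 19900 nM

Compound 2 gives the highest of the three numbers in this assay. Its nearest neighbour is compound 3, with a step of a 1.1-fold lower number from compound 2 to compound 3 (0.06 log units; within the scatter), so the two cannot be told apart on this read-out. Its furthest neighbour is compound 1, reached by the step of a 2.3-fold higher number from compound 1 to compound 2 (0.36 log units; beyond the scatter), which does exceed the scatter.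

Compound 4, `CCCCOC(=O)Nc1ccc([Se]C#N)cc1`, has not yet been measured in this assay. Relative to compound 2 the change is butyl in place of phenyl on an oxygen next to a carbonyl group.

For the measured compounds named here, only one measured step bears on this change: the step from compound 1 to compound 2, a 2.3-fold higher number from compound 1 to compound 2 (0.36 log units; beyond the scatter), where phenyl replaced allyl on the same oxygen. Compound 4 carries butyl in that place, so the change from compound 2 to compound 4 is close to the reverse of that step. The step from compound 2 to compound 3 concerns a different position and gives no guidance here. A modest step towards a lower number in this assay is therefore expected, of roughly the size seen in a 2.3-fold higher number from compound 1 to compound 2 (0.36 log units; beyond the scatter).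

Compound 4 is estimated at 10000 nM, with a range of 4000 nM to 25000 nM. This estimate means an expected step of a 2.3-fold lower number from compound 2 to compound 4 (0.36 log units; beyond the scatter).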

Compound 4, concentration for total growth inhibition: 14500 nM
Beside the measured number, compound 4's estimate is 1.5-fold (0.16 log units) below it, and the stated range covers the measured number.
By their numbers in this assay, from the lowest: compounds 1, 4, 3 and 2 (each within the scatter of the next, the first and the last beyond it).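

In this assay, butyl in place of phenyl on an oxygen next to a carbonyl group gives a 1.6-fold lower number from compound 2 to compound 4 (0.19 log units; within the scatter), and the change at the end of the allyl chain gives a 1.5-fold higher number from compound 1 to compound 4 (0.17 log units; within the scatter), so compound 4 cannot be told apart on this read-out from either compound 2 or compound 1. The step of a 2.3-fold higher number from compound 1 to compound 2 (0.36 log units; beyond the scatter) therefore remains the only one at this position beyond the scatter, and with butyl falling within the scatter of both allyl and phenyl, the series draws no clear line between open chains and the aromatic ring at this oxygen. No measured information accompanies these numbers that could account for them.

Still open, as far as these compounds go, is whether a longer chain, a saturated ring such as cyclohexyl, or a chain ending in an amine or a carboxylic acid at this oxygen would move the number beyond the scatter relative to compound 4. For the compounds shown here, also open is whether chloro on the aromatic ring would remain within the scatter with other groups on the carbamate oxygen, since only the step from compound 2 to compound 3 speaks to it.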